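Swapping an amide chain for a hydroxamic acid cyclopropane

The compounds below may be only part of what the source reports. "The series", "measured", "known", "first", "only" and "open" are said of these compounds alone.

Measured so far:
- compound 1, `CC(C)(Oc1ccc(NCc2cccc(Oc3ccccc3)c2)cc1)C(=O)O`, with a limit of < 10000 nM in a functional assay on CHO cells for agonist activity at Free fatty acid receptor 1 (Homo sapiens); on this read-out lower numbers stand for an effect already at smaller amounts and higher numbers for an effect only at larger amounts of compound
- compound 2, `CC(C)NC(=O)CCc1ccc(NCc2cccc(Oc3ccccc3)c2)cc1`, with 39.8 nM in this assay

Among the measured compounds shown here, compound 2 holds the only real number in this set. In this assay compound 2 gives 39.8 nM. For compound 1 only a limit is known, < 10000 nM in this assay, so it does not give a number. The step that the limit leaves unreadable from compound 1 to compound 2 cannot be sized, since one end of it sits at the limit described by the limit of < 10000 nM in this assay, at which 1 of the 2 values shown sits.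

Compound 3, `O=C(NO)[C@H]1C[C@@H]1c1ccc(NCc2cccc(Oc3ccccc3)c2)cc1`, differs from compound 2 by 2-(hydroxycarbamoyl)cyclopropyl in place of 2-(isopropylcarbamoyl)ethyl on an aromatic carbon. For the measured compounds named here, no measured step involves a 2-(hydroxycarbamoyl)cyclopropyl group, and the one step known is unreadable, so nothing among the measurements sets the size of this change. The step from compound 2 to compound 3 is therefore expected only loosely, with room for a loss beyond the scatter, and the estimate of a 3.8-fold higher number from compound 2 to compound 3 (0.58 log units; beyond the scatter) reflects that uncertainty. Compound 3 is expected to give about 150 nM in this assay, within a range from 30 nM to 800 nM.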

Compound 3, half-maximal effective concentration: 14.8 nM
For compound 3 the middle estimate is 10-fold (1.01 log units) above the measured one, and the stated range ends above it.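

In this assay, putting 2-(hydroxycarbamoyl)cyclopropyl in place of 2-(isopropylcarbamoyl)ethyl gives a 2.7-fold lower number from compound 2 to compound 3 (0.43 log units; beyond the scatter). Among the compounds shown here, this is the first readable comparison at this position, on an aromatic carbon and para to a large group, and it shows that the 2-(isopropylcarbamoyl)ethyl group is not needed for an effect at low concentrations: a shorter group with a three-membered ring and two defined stereocentres does somewhat better on the same core. The steps from compound 1 to compound 2 and to compound 3 cannot be read, because compound 1 carries only a limit and not a number: the limit of < 10000 nM in this assay, at which 1 of the 3 values shown sits.

The change replaces the open chain with a ring and the isopropyl amide with a hydroxamic acid in one move, so the compounds shown cannot say which of the two accounts for the step. As far as these compounds go, a 2-(hydroxycarbamoyl)ethyl group would separate them from one side and an isopropyl amide on the cyclopropane from the other, while a carboxylic acid on the same ring and the opposite arrangement of the two stereocentres also remain open.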